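The source may hold more compounds than are shown below. What is called first, only, known or untested is meant among the compounds shown, and "the series" means these compounds.

Of the compounds shown here, three measured so far share one core: compound 1 `Cc1ccc(-n2cc(-c3ccccc3NS(=O)(=O)c3c[nH]c(=O)[nH]c3=O)nn2)cc1`, compound 2 `O=c1[nH]cc(S(=O)(=O)Nc2ccccc2-c2cn(-c3ccccc3F)nn2)c(=O)[nH]1` and compound 3 `Cc1ccccc1-n1cc(-c2cccc(NS(=O)(=O)c3c[nH]c(=O)[nH]c3=O)c2)nn1`. In a functional assay on A549 cells (Homo sapiens) for antiproliferative activity, read by MTT assay, with a stated time of 24 h (a higher number here means a weaker inhibitor, a lower number a stronger inhibitor), compound 1 gives 2910 nM, compound 2 gives 7370 nM and compound 3 gives 5470 nM. Compound 3 stands within the scatter of both compound 1 and compound 2, so its number sets it apart from neither. Among the measured compounds shown here, the one step beyond the scatter is a 2.5-fold higher number from compound 1 to compound 2 (0.40 log units; beyond the scatter), an exchange of 4-methylphenyl for 2-fluorophenyl on an aromatic nitrogen.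

Compound 4 `O=c1[nH]cc(S(=O)(=O)Nc2cccc(-c3cn(-c4ccccc4F)nn3)c2)c(=O)[nH]1` has not yet been measured. It differs from compound 3 by fluoro in place of methyl on an aromatic carbon, so that the pair from compound 3 to compound 4 reads 2-methylphenyl to 2-fluorophenyl. For the measured compounds named here, the only measured step that bears on this is the one from compound 1 to compound 2, which also trades a methyl-bearing phenyl for a fluoro-bearing phenyl on the same nitrogen and gave a modest rise in number. That step is not the identical exchange, so the guidance is loose. A modest rise of similar size, a 1.8-fold higher number from compound 3 to compound 4 (0.26 log units; within the scatter), is therefore expected. Compound 4 is estimated to give 10000 nM in this assay, with a range from 4500 nM to 22000 nM.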

Compound 4, half-maximal inhibitory concentration: > 20000 nM
Compound 4: no number, only a limit (the forecaster's own chance of this, stated with the estimate: 5%); at least 2.0-fold (0.30 log units) between middle value and limit.
By their numbers in this assay, from the lowest: compounds 1, 3 and 2 (each within the scatter of the next, the first and the last beyond it). At a limit, above all of these: compound 4.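

Set against 2-methylphenyl, the 2-fluorophenyl group differs only in the atom on an aromatic carbon ortho to a large group, and this single exchange gives an at least 3.6-fold higher number from compound 3 to compound 4 (0.56 log units; beyond the scatter), so the outcome in this series is sensitive to that one substituent. Compound 4 gives no number in this assay, only a limit, the single one among the compounds shown: the limit of > 20000 nM in this assay, at which 1 of the 4 values shown sits. The earlier step, a 2.5-fold higher number from compound 1 to compound 2 (0.40 log units; beyond the scatter), also ended on 2-fluorophenyl but started from 4-methylphenyl, so it changed the substituent and its place together, whereas the new step changes the substituent alone and shows that a higher number follows in a second pair as well, with neither of these two steps going against it.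

From the compounds shown here alone, how far the true value of compound 4 lies past its limit stays open, and so the full size of the step and any comparison of it with the earlier one remain unknown. Also open, going by these compounds, is how a chloro, a methoxy or an amine at this same place would read, and whether an unsubstituted phenyl would stand closer to the methyl or to the fluoro compound.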